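A few compounds are considered here, and "the series" means these few. Any claim that something is new, unique, unknown or untested is made for them only; others in the source may bear on it.

Measured so far:
compound 1, `Cc1nc2sc(Nc3ccc(Cl)cc3)nc2c(=O)[nH]1`: 49%
compound 2, `Cc1nc2sc(Nc3cccc(Cl)c3)nc2c(=O)[nH]1`: 48%

Both were tested in an assay on CHO cells for displacement of a labelled ligand from adenosine receptor A3 (Homo sapiens), read by scintillation counting, with a stated time of 120 min, tested at 1 uM; a higher number here means more inhibition at the concentration tested (going by the name of the read-out), a lower number less inhibition. Within the data shown here, compound 2 gives 48%, and the only other number, from compound 1 at 49%, lies within the scatter of it, so the two cannot be told apart. Compound 3 `Cc1nc2sc(Nc3ccc(Cl)c(Cl)c3)nc2c(=O)[nH]1` has not yet been measured in this assay. Relative to compound 2 it carries chloro in place of hydrogen on an aromatic carbon. Among the measured compounds shown here, no step of this kind exists among the measured compounds, so the change is expected to be small, at most a modest rise: the expected step is a number 7 percentage points higher from compound 2 to compound 3 (within the scatter), barely beyond the scatter. Compound 3 is estimated to give 55%, with a likely range from 30% to 75%.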

Compound 3, a percentage reported as inhibition, at one concentration (the size of the read-out at that concentration, not a potency): 25%
Beside the measured number, compound 3's estimate is 30 percentage points above it; the whole stated range lies above it.
By their numbers in this assay, from the lowest: compound 3; then compounds 2 and 1 (each within the scatter of the next).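

Chloro in place of hydrogen, ortho to a chloro group and para to a large group, gives a number 23 percentage points lower from compound 2 to compound 3 (beyond the scatter) in this assay and, counted from the other compound with a single chloro, the second chloro gives a number 24 percentage points lower from compound 1 to compound 3 (beyond the scatter) in the same read-out. Compound 1 and compound 2 could not be told apart, so only this second chloro shows that the ring's substitution can lower inhibition at the concentration tested. Nothing at hand accounts for the drop. On these data alone, it remains open whether it belongs to chloro itself or would also follow a fluoro, methyl or methoxy group at this place, and whether an amine there would behave alike.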